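From nitro to cyano near an assay limit

This account rests on a few compounds, and the source may have more. Where it says the series, first, only, none or still open, it means among the compounds named here.

compound 1 `COc1cc(OC)c(-c2coc3cc(OCC(=O)c4cccc(C(F)(F)F)c4)ccc3c2=O)cc1OC`: > 10000 nM (a limit)
compound 2 `COc1cc(OC)c(-c2coc3cc(OCc4ccccc4F)ccc3c2=O)cc1OC`: 2900 nM
compound 3 `COc1cc(OC)c(-c2coc3cc(OCc4ccc([N+](=O)[O-])cc4)ccc3c2=O)cc1OC`: > 10000 nM (a limit)

All three values come from a functional assay on HCT-116 cells (Homo sapiens) for antiproliferative activity, read by MTT assay, with a stated time of 24 h (a higher number here means a weaker inhibitor, a lower number a stronger inhibitor), and the main feature of this small series is the limit of > 10000 nM in this assay, at which 2 of the 3 values shown sit, for now. On these data alone, compound 3 gives > 10000 nM and this is a limit, not a number, so its true place is unknown.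

Compound 4 `COc1cc(OC)c(-c2coc3cc(OCc4ccc(C#N)cc4)ccc3c2=O)cc1OC` differs by one group, with cyano in place of nitro on an aromatic carbon, para to a large group (cyano in place of nitro on an aromatic carbon). Among the measured compounds shown here, no measured step makes this exact swap. The closest is an at least 3.4-fold higher number from compound 2 to compound 3 (0.53 log units; beyond the scatter) as 4-nitrophenyl replaces 2-fluorophenyl, so a change on this ring can matter. The step that the two limits leave unreadable from compound 1 to compound 3 gives no usable size, while an at least 3.4-fold lower number from compound 1 to compound 2 (0.53 log units; beyond the scatter) shows that a readable number is possible here.

For the measured compounds named here, only a modest move towards a lower number is expected, resting on compound 2 at 2900 nM as the one readable value. The expected step is an at least 1.1-fold lower number from compound 3 to compound 4 (0.04 log units; that floor lies within the scatter) and it may stay unreadable. For compound 4 the estimated value is 9000 nM with an expected range from 3000 nM to 25000 nM. A limit rather than a readable number is also possible for compound 4.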

Compound 4, half-maximal inhibitory concentration: 4220 nM
The estimate for compound 4 lay 2.1-fold (0.33 log units) above the measured number; the range from low to high includes it.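

In this assay, among the compounds shown here, the first direct look at this position shows that exchanging nitro for cyano on the aromatic carbon para to a large group gives an at least 2.3-fold lower number from compound 3 to compound 4 (0.37 log units; beyond the scatter), so this one small swap brings the series back to a readable number. The 4-cyanophenyl group and the 2-fluorophenyl group give a 1.5-fold higher number from compound 2 to compound 4 (0.16 log units; within the scatter), so the two compounds cannot be told apart here, and a readable number is no longer tied to a single substituted ring. The other new step, an at least 2.3-fold lower number from compound 1 to compound 4 (0.37 log units; beyond the scatter), also starts from a limit, so it and the nitro-to-cyano step each give a floor and not a true size: the limit of > 10000 nM in this assay, at which 2 of the 4 values shown sit.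

On these data alone, the real size of both steps stays unknown. As far as these compounds go, it also stays open whether an amine or a carboxylic acid in the same place would give a readable number.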